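The compounds below may be only part of what the source reports. "The series", "measured", "known", "first", "only" and "open" are said of these compounds alone.

Compound 1, `COc1ccc2ncc(S(=O)(=O)c3ccc(OC)c(Cl)c3)c(N3CCC(C)CC3)c2c1`, gives 21%; compound 2, `COc1ccc2ncc(S(=O)(=O)c3ccc(C)c(F)c3)c(N3CCC(C)CC3)c2c1`, gives 73%; compound 3, `COc1cccc(S(=O)(=O)c2cnc3ccc(F)cc3c2N2CCC(C)CC2)c1`, gives 90% in an assay on isolated protein for displacement of a labelled ligand from metabotropic glutamate receptor 5 (Homo sapiens), with a stated time of 60 min, tested at 1 uM; on this read-out lower numbers stand for less inhibition and higher numbers for more inhibition at the one concentration tested (going by the name of the read-out).

Compound 3 stands highest of the three numbers, with compound 2 nearest and compound 1 furthest, both gaps beyond the scatter. Compound 4, `COc1cccc(S(=O)(=O)c2cnc3ccc(OC)cc3c2N2CCC(C)CC2)c1`, differs from compound 3 in one place: methoxy in place of fluoro on an aromatic carbon. Among the measured compounds shown here, the only measured step, a number 52 percentage points higher from compound 1 to compound 2 (beyond the scatter), concerns the aryl on the sulfonyl sulfur and does not bear on this change; the two methoxy-bearing compounds 1 and 2 differ from compound 3 in that aryl as well. With nothing directly comparable, only a modest change is expected for compound 4, a number 12 percentage points lower from compound 3 to compound 4 (beyond the scatter), and its value in this assay is estimated at 78%, between 52% and 95%.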

Compound 4, a percentage reported as inhibition, at one concentration (the size of the read-out at that concentration, not a potency): 0%
Compound 4: middle estimate off by 78 percentage points, on the high side; the measured number lies below the stated range.
By their numbers in this assay, from the lowest: compound 4; then compound 1; then compound 2; then compound 3.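

At this aromatic carbon of the core, methoxy in place of fluoro abolishes the signal in this assay, with a number 90 percentage points lower from compound 3 to compound 4 (beyond the scatter). The 3-methoxyphenyl on the sulfonyl sulfur therefore does not hold its high number whatever the core carries: with methoxy on the core it falls short of both other aryls, with a number 73 percentage points lower from compound 2 to compound 4 (beyond the scatter) and a number 21 percentage points lower from compound 1 to compound 4 (beyond the scatter). Nothing given here offers a reason for this loss.

From the compounds shown here alone, whether methoxy harms only alongside 3-methoxyphenyl stays open, since compound 1 and compound 2 keep measurable inhibition with it. Going by these compounds, how ethoxy, hydroxy or an amine would fare at this carbon also stays open.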